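The compounds below may be only part of what the source reports. "The series", "measured", "known", "first", "only" and "open" are said of these compounds alone.

Compound 1, `CCn1c(-c2cnc(C)nc2)nc2c(O[C@H]3CCN(C(=O)C4CC4)C3)ncnc21`, is the starting point. In an ADME assay (Rattus norvegicus, strain Wistar Han) for pharmacokinetics (on this read-out higher numbers stand for wider distribution into tissues and lower numbers for narrower distribution), compound 1 gives 2.8 L/kg, the lowest of the three numbers recorded so far. Compound 3, `CCC(=O)N1CC[C@H](Nc2ncnc3c2nc(-c2cnc(C)nc2)n3CC)C1`, gives 3.6 L/kg in this assay; it differs from compound 1 in more than one place, and the two values lie within the scatter of each other. For the measured compounds named here, compound 2, `CCn1c(-c2ccc(C(F)(F)F)nc2)nc2c(O[C@H]3CCN(C(=O)C4CC4)C3)ncnc21`, gives 8.3 L/kg, and the step of a 3.0-fold higher number from compound 1 to compound 2 (0.47 log units; beyond the scatter) is the only single-place change measured, made by putting 6-(trifluoromethyl)pyridin-3-yl in place of 2-methylpyrimidin-5-yl on an aromatic carbon.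

Compound 4, `CCn1c(-c2cnc(C)nc2)nc2c(O[C@H]3CCN(C(=O)N4CC(OC)C4)C3)ncnc21`, has not yet been measured. It differs from compound 1 as follows: 3-methoxyazetidin-1-yl in place of cyclopropyl on a carbonyl carbon. Going by the values given here, this change sits on a carbonyl carbon whose other neighbour is an amide-type nitrogen in a ring, far from the aromatic carbon altered in the one measured step. Among the compounds with values here, no measured pair therefore bears directly on it, and the step of a 3.0-fold higher number from compound 1 to compound 2 (0.47 log units; beyond the scatter) offers no guide for a change at the carbonyl. With nothing to lean on, the expected step of a 1.4-fold lower number from compound 1 to compound 4 (0.15 log units; within the scatter) is small, on the lower side, and may well lie within the scatter. Compound 4 is estimated to give 2 L/kg in this assay, within a range from 1 L/kg to 4 L/kg.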

Compound 4, volume of distribution: 2.1 L/kg
Compound 4: the middle estimate sits 1.1-fold (0.02 log units) below what was measured, and the stated range covers the measured number.
By their numbers in this assay, from the lowest: compounds 4, 1 and 3 (each within the scatter of the next); then compound 2.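

In this assay, for the compounds shown here, this is the first single change at the carbonyl carbon, and a 1.3-fold lower number from compound 1 to compound 4 (0.12 log units; within the scatter) lies within the scatter, so the two compounds cannot be told apart on this read-out. Here, cyclopropyl, with 3 heavy atoms and no hydrogen-bond acceptor, gives way to 3-methoxyazetidin-1-yl, with 6 heavy atoms and 1 hydrogen-bond acceptor, without a step that can be distinguished from the scatter, whereas the change on the aromatic carbon, a 3.0-fold higher number from compound 1 to compound 2 (0.47 log units; beyond the scatter), lies beyond it. Nothing available explains why this larger replacement leaves the number within the scatter.

A single pair cannot show whether other groups on this carbonyl would behave the same way, such as azetidin-1-yl without its methoxy, a longer carbon chain, an amine or a carboxylic acid. It also leaves open whether the step seen with 6-(trifluoromethyl)pyridin-3-yl would carry over to a compound that has 3-methoxyazetidin-1-yl on the carbonyl carbon.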